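The compounds below may be only part of what the source reports. "The series", "measured", "known", "first", "only" and "open" are said of these compounds alone.

Compound 1 `Nc1cc(N)c2nc(-c3ccccc3)c(NCc3ccc(F)cc3)nc2c1` was tested in a functional assay on PC-3 cells (Homo sapiens) for inhibition, read by sulforhodamine B assay, with a stated time of 48 h (on this read-out lower numbers stand for higher toxicity in this test and higher numbers for lower toxicity in this test), and gave < 100000 nM, which is a limit of the test rather than a measured number. Its close relative compound 2 `COc1ccc(CNc2nc3cc(N)cc(N)c3nc2-c2ccccc2)cc1` gives 72400 nM in this assay. The move from compound 1 to compound 2 is a step that the limit leaves unreadable from compound 1 to compound 2; its size stays unreadable because of the limit of < 100000 nM in this assay, at which 1 of the 2 values shown sits. Compound 3 `Nc1cc(N)c2nc(-c3ccccc3)c(Sc3ccc(F)cc3)nc2c1` has not yet been measured. It differs from compound 1 by (4-fluorophenyl)sulfanyl in place of (4-fluorobenzyl)amino on an aromatic carbon. For the measured compounds named here, the only measured step, from compound 1 to compound 2, touches a different part of the molecule and its size is unknown, so it offers no guide to the exchange that leads to compound 3. Compound 1 itself stands only at a limit. The step from compound 1 to compound 3 is expected to be a step that the limit leaves unreadable from compound 1 to compound 3, with no direction claimed beyond the usual scatter. Compound 3 is therefore expected to give about 50000 nM in this assay, within a range from 10000 nM to 100000 nM.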

Compound 3, concentration lethal to 50% of the cells: < 100000 nM
Compound 3 ended at the assay's limit; the forecaster's own chance of this, stated with the estimate: 35%; the middle value does not contradict the limit.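

For the compounds shown here, compound 1 and compound 3 both stand only at a limit, so no step between them can be read: the limit of < 100000 nM in this assay, at which 2 of the 3 values shown sit. The compounds shown leave open whether (4-fluorophenyl)sulfanyl in place of (4-fluorobenzyl)amino changes the result in this assay, and in which direction.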